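This account rests on a few compounds, and the source may have more. Where it says the series, first, only, none or still open, it means among the compounds named here.

Among the compounds with values here, compound 3, `CC[C@@H](Nc1c(C#N)c(-c2ccc(-c3cccc(OC)c3)cc2)nc2cnccc12)C(N)=O`, stands highest in a physicochemical assay for lipophilicity, read by HPLC, at pH 7.5 (on this read-out higher numbers stand for higher lipophilicity and lower numbers for lower lipophilicity), among the three compounds measured so far, with a reading of 2.7. Its nearest neighbour on this scale is compound 2, `CCOc1ccccc1-c1ccc(-c2nc3cnccc3c(C[C@H](C)C(=O)O)c2C#N)cc1`, whose reading in this assay is 2.2, a gap beyond the scatter. Furthest from it is compound 1, `CCOc1ccccc1-c1ccc(-c2nc(NC(C)C(=O)O)c3ccncc3n2)cc1`, which in this assay gives 2.1, again beyond the scatter. Within the data shown here, compounds 1 and 2 share the ethoxyphenyl-bearing biaryl, while compound 3 carries a methoxyphenyl instead; no single-point step joins any two of them, so only the bare values can be compared.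

The next compound, compound 4, `CC[C@@H](Nc1c(C#N)c(-c2ccc(Br)cc2)nc2cnccc12)C(N)=O`, differs from compound 3 in one place: bromo in place of 3-methoxyphenyl on an aromatic carbon. Among the measured compounds shown here, with no measured pair of this kind to draw on, the expectation rests on the size of what leaves and what enters. Compound 4 is expected to sit clearly lower than compound 3, with an estimated step of a number 1.00 log units lower from compound 3 to compound 4 (beyond the scatter) in this assay. The estimated reading for compound 4 is 1.7, within a range from 1.2 to 2.3.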

Compound 4, distribution coefficient: 2.2
Estimate against measurement, compound 4: 0.50 log units below, within the range that was stated.
By their numbers in this assay, from the lowest: compounds 1, 2 and 4 (each within the scatter of the next); then compound 3.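

Within the data shown here, this is the first step in the set that can be read at a single point. In this assay, bromo in place of 3-methoxyphenyl, on an aromatic carbon para to a large group, gives a number 0.50 log units lower from compound 3 to compound 4 (beyond the scatter). The change therefore registers in the read-out at this position, although the step is modest for a swap that replaces a whole aromatic ring and 8 heavy atoms with 1 heavy atom. Nothing shown here accounts for the size of this step.

From the compounds shown here alone, with one pair, it stays open whether the ring, its methoxy group or the bromine sets the step, and a plain phenyl, a chloro or a lone methoxy at this place could separate these. Going by these compounds, it also stays open whether the same exchange would give a similar step on another core.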